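The source may hold more compounds than are shown below. What is called first, only, known or untested is meant among the compounds shown, and "the series" means these compounds.

Compound 1, `COc1cccc(OC)c1C(=O)Nc1nnc(-c2ccc(C)cc2)s1`, gives 85.1 nM. Compound 2, `COc1cccc(OC)c1C(=O)Nc1nnc(-c2ccc(F)cc2)s1`, gives 89.1 nM. Compound 3, `COc1cccc(OC)c1C(=O)Nc1nnc(-c2ccc(C#N)cc2)s1`, gives 200 nM.

These are the numbers from a functional assay on the whole organism (integument) for inhibition, with Chilo suppressalis as the target, read by scintillation counting, with a stated time of 72 h, in the presence of a further agent that is not named here; on this read-out lower numbers stand for stronger inhibition and higher numbers for weaker inhibition. Compound 2 and compound 1 sit within the scatter of each other, as a 1.0-fold higher number from compound 1 to compound 2 (0.02 log units; within the scatter) shows, while compound 3 gives a higher number than both, with a 2.2-fold higher number from compound 2 to compound 3 (0.35 log units; beyond the scatter) and a 2.4-fold higher number from compound 1 to compound 3 (0.37 log units; beyond the scatter).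

Compound 4, `COc1cccc(OC)c1C(=O)Nc1nnc(-c2ccc(-c3ccccc3)cc2)s1`, is reached from compound 2 by phenyl in place of fluoro on an aromatic carbon. Among the compounds with values here, none of the measured steps puts a phenyl on this aromatic carbon. What they do show is that the group on this carbon matters only modestly: methyl and fluoro are interchangeable within the scatter, and cyano raises the number by a modest step in this assay. A phenyl is a far larger group than any of the three, so the measured steps give only a loose guide. The expectation is therefore a step of a 1.5-fold higher number from compound 2 to compound 4 (0.16 log units; within the scatter), leaning toward a somewhat higher number but with wide uncertainty. Compound 4 is estimated at 130 nM, with a range from 40 nM to 450 nM.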

Compound 4, half-maximal inhibitory concentration: 117 nM
Beside the measured number, compound 4's estimate is 1.1-fold (0.05 log units) above it; the range from low to high includes it.
By their numbers in this assay, from the lowest: compounds 1, 2, 4 and 3 (each within the scatter of the next, the first and the last beyond it).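

In this assay, the exchange of fluoro (1 heavy atom) for phenyl (6 heavy atoms, with a ring of its own) gives a 1.3-fold higher number from compound 2 to compound 4 (0.12 log units; within the scatter), and the exchange of methyl for phenyl gives a 1.4-fold higher number from compound 1 to compound 4 (0.14 log units; within the scatter). Within the data shown here, this aromatic carbon therefore carries a whole aromatic ring without a step that can be told from the scatter, which the small groups in the earlier compounds could not show; even against cyano, the exchange gives a 1.7-fold lower number from compound 3 to compound 4 (0.23 log units; within the scatter), so compound 4 cannot be separated from any of the three, although compound 3 stands apart from compound 1 and compound 2. Nothing given here accounts for this result.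

The compounds shown leave open whether this carbon accepts groups of other kinds as readily, such as an amine, a carboxylic acid or a longer alkyl chain, since all four carry groups with no hydrogen-bond donor. They also leave open whether a substituent on the added phenyl, for example a methoxy group or a chlorine atom, would move the number beyond the scatter.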